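The compounds below may be only part of what the source reports. "The series", "measured", "known", "first", "only" and "open" are said of these compounds alone.

Three compounds have been measured in an assay on membranes from HEK293 cells for displacement of a labelled ligand from adenosine receptor A2b (Homo sapiens), read by scintillation counting, with a stated time of 30 min, tested at 1 uM; on this read-out higher numbers stand for more inhibition at the one concentration tested (going by the name of the read-out) and lower numbers for less inhibition:
Compound 1, `CCCOC(=O)C1=C(C)N(C)C(=O)NC1c1ccsc1`, gives 1%.
Compound 2, `CC1=C(C(=O)OCC(C)C)C(c2ccsc2)NC(=O)N1C`, gives 1%.
Compound 3, `CCSC(=O)C1=C(C)NC(=O)NC1c1ccsc1`, gives 17%.

Compound 2 differs from compound 1 by methyl in place of hydrogen on a saturated chain carbon bound to two saturated chain carbons, and the step is no change at the digits printed from compound 1 to compound 2 (within the scatter). Compound 3 stands highest of the three, beyond the scatter from both compound 1 and compound 2; how its core differs from the core of compound 1 is not broken down here. Compound 4, `CC1=C(C(=O)SC(C)C)C(c2ccsc2)NC(=O)N1`, is not yet measured and differs from compound 3 by methyl in place of hydrogen on a saturated chain carbon bound to a saturated chain carbon and a sulfur. This is the same kind of change as that from compound 1 to compound 2, not the same: there the place was a saturated chain carbon bound to two saturated chain carbons, here a saturated chain carbon bound to a saturated chain carbon and a sulfur. Because the earlier step of no change at the digits printed from compound 1 to compound 2 (within the scatter) stayed within the scatter, the step to compound 4 is expected to be small, estimated as a number 1 percentage points lower from compound 3 to compound 4 (within the scatter). Compound 4 is estimated at 16%, with a range from 3% to 32%.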

Compound 4, a percentage reported as inhibition, at one concentration (the size of the read-out at that concentration, not a potency): 14%
For compound 4 the middle estimate is 2 percentage points above the measured one; the measured number falls inside the stated range.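

In this assay the added methyl gives a number 3 percentage points lower from compound 3 to compound 4 (within the scatter). Within the data shown here, on both cores, the step is small and the two steps agree: the same change on two cores in this assay, no change at the digits printed (within the scatter) from compound 1 to compound 2 and a number 3 percentage points lower (within the scatter) from compound 3 to compound 4, 3 percentage points apart, within the scatter of two such steps This shows only that the change left the read-out within the scatter on these two cores, at two slightly different places, and it does not show that the agreement would hold on a third core or for a larger group.

The compounds shown leave open what a longer chain, an amine or a carboxylic acid would do in place of the isopropyl group. They also leave open which of the differences between the core of compound 1 and the core of compound 3 goes with the gap in their values.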